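The source may hold more compounds than are shown below. What is called first, only, known or untested is meant among the compounds shown, and "the series" means these compounds.

Measured so far:
compound 1 `CC(C)S(=O)(=O)N1CCN(c2cnn(-c3cccc(F)c3)c(=O)c2OC2CCCC2)CC1` gives 670 ng.h/mL in an ADME assay on the whole organism for pharmacokinetics, with Rattus norvegicus as the target, with a stated time of 6 h, at a dose of 10 mg/kg by the oral route; a higher number here means more compound in the circulation at the dose given, a lower number less compound in the circulation
compound 2 `CC(C)S(=O)(=O)N1CCN(c2cnn(-c3cccc(F)c3)c(=O)c2OC2CCC(F)C2)CC1` gives 300 ng.h/mL in this assay
compound 3 `CC(C)S(=O)(=O)N1CCN(c2cnn(-c3cc(F)cc(F)c3)c(=O)c2OC2CCC(F)(F)C2)CC1` gives 440 ng.h/mL in this assay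

Compound 3 stands second highest of the three numbers, but both gaps are within the scatter: compound 2 sits a little lower and compound 1 a little higher. Compound 4 `CC(C)S(=O)(=O)N1CCN(c2cnn(-c3cccc(F)c3)c(=O)c2OC2CCC(F)(F)C2)CC1` differs from compound 3 by hydrogen in place of fluoro on an aromatic carbon. Among the measured compounds shown here, the only measured step, a 2.2-fold lower number from compound 1 to compound 2 (0.35 log units; beyond the scatter), concerns a fluoro on a saturated ring and does not bear on a change at the aromatic ring. Compound 2 and compound 3, which differ only at the saturated ring, lie within the scatter of one another. No step beyond the scatter is therefore expected in this assay. Compound 4 is estimated at 450 ng.h/mL, with a range from 200 ng.h/mL to 1000 ng.h/mL. The expected step is a 1.0-fold higher number from compound 3 to compound 4 (0.01 log units; within the scatter).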

Compound 4, area under the concentration-time curve: 470 ng.h/mL
The estimate for compound 4 lay 1.0-fold (0.02 log units) below the measured number, within the range that was stated.
By their numbers in this assay, from the lowest: compounds 2, 3, 4 and 1 (each within the scatter of the next, the first and the last beyond it).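

Hydrogen in place of fluoro on this aromatic carbon gives a 1.1-fold higher number from compound 3 to compound 4 (0.03 log units; within the scatter) in this assay and so does not separate the 3,5-difluorophenyl group from the 3-fluorophenyl group. With the 3-fluorophenyl group held constant, a 1.6-fold higher number from compound 2 to compound 4 (0.19 log units; within the scatter) and a 1.4-fold lower number from compound 1 to compound 4 (0.15 log units; within the scatter) place the 3,3-difluorocyclopentyl compound within the scatter of both other compounds, although a 2.2-fold lower number from compound 1 to compound 2 (0.35 log units; beyond the scatter) stands between those two.

Open, from the compounds shown here alone, is whether a methoxy group or a nitrile on this aromatic carbon would give a step beyond the scatter. No supporting data are available to explain these results.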